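The source may hold more compounds than are shown below. What is called first, only, known or untested is meant among the compounds shown, and "the series" means these compounds.

Compound 1 `COc1ccc(N(C)c2ncnc3c2ncn3Cc2cc(OC)c(OC)c(OC)c2)cc1`: 260 nM
Compound 2 `COc1ccc(Cn2cnc3c(Cl)ncnc32)cc1OC`: > 100000 nM (a limit)
Compound 3 `COc1cc(Cn2cnc3c(Cl)ncnc32)cc(OC)c1`: > 100000 nM (a limit)

In a functional assay on SH-SY5Y cells (Homo sapiens) for antiproliferative activity, read by MTT assay, with a stated time of 48 h (on this read-out higher numbers stand for weaker inhibition of growth and lower numbers for stronger inhibition of growth), compound 3 gives > 100000 nM, which is a limit and not a number. Compound 2 likewise gives only a limit, > 100000 nM. Compound 4 `COc1cc(Cn2cnc3c(Cl)ncnc32)cc(OC)c1OC` is compound 3 with methoxy in place of hydrogen on an aromatic carbon. Compound 4 keeps the chlorine of compound 2 and compound 3, not the larger group of compound 1, which gives 260 nM. For the measured compounds named here, no measured pair shows this change on its own, so in this assay only a small gain in growth inhibition, or none beyond the scatter, is expected. The expected step is an at least 1.4-fold lower number from compound 3 to compound 4 (0.15 log units; that floor lies within the scatter). For compound 4 the estimated value is 70000 nM, with an expected range of 15000 nM to 100000 nM.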

Compound 4, concentration for 50% growth inhibition: > 100000 nM
Compound 4 gave a limit, no number; the forecaster's own chance of this, stated with the estimate: 70%; at least 1.4-fold (0.15 log units) between middle value and limit.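

In this assay, the added methoxy, ortho to two methoxy groups, does not lift the chlorine series off the limit: compound 4 gives > 100000 nM, which is a limit and not a number. The steps from compound 2 and compound 3 to compound 4 cannot be read because of where these values sit: the limit of > 100000 nM in this assay, at which 3 of the 4 values shown sit. Compound 4 now matches compound 1 everywhere except one place, and chloro in place of (4-methoxyphenyl)(methyl)amino gives an at least 380-fold higher number from compound 1 to compound 4 (2.58 log units; beyond the scatter).

Still open, from the compounds shown here alone, is whether a simple amine in place of chloro would restore growth inhibition, or whether the whole (4-methoxyphenyl)(methyl)amino group is needed. Also open, going by these compounds, is what this methoxy does when that larger group is present.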